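Benzyl for thiophen-2-yl on two related cores

This account rests on a few compounds, and the source may have more. Where it says the series, first, only, none or still open, it means among the compounds named here.

Measured in an ADME assay on S9 fraction from liver (Rattus norvegicus) for metabolic stability, read by LC-MS, using NADPH, with a stated time of 30 min; on this read-out lower numbers stand for a less stable compound and higher numbers for a more stable compound:
compound 1 `CCCCCCCCc1ccc(OCC(=O)Cn2nnc(-c3cccs3)n2)cc1`: 8%
compound 2 `CCCCCCCCc1ccc(OCC(=O)Cn2nnc(Cc3ccccc3)n2)cc1`: a limit of the assay, < 5%
compound 3 `CCCCCCCCc1ccc(OCC(=O)Cn2nnnc2-c2cccs2)cc1`: 27%

Compound 2 gives only a limit of the assay, < 5%; see (the limit of < 5% in this assay, at which 1 of the 3 values shown sits). The change benzyl in place of thiophen-2-yl on an aromatic carbon gave a number at least 3 percentage points lower from compound 1 to compound 2 (that floor lies within the scatter). Compound 3 holds the highest of the two numbers; the difference between its core and the core of compound 1 is not broken down here.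

Compound 4 `CCCCCCCCc1ccc(OCC(=O)Cn2nnnc2Cc2ccccc2)cc1` is not yet measured. It differs from compound 3 by benzyl in place of thiophen-2-yl on an aromatic carbon. The surroundings of the place differ from those in the step from compound 1 to compound 2: here the group sits next to the ring atom that bears a large group and two ring bonds from the ring nitrogen, whereas there it sits two ring bonds from the ring nitrogen and two ring bonds from the ring atom that bears a large group; so it is the same kind of change, not the same. From compound 3 to compound 4 a step of a number 15 percentage points lower from compound 3 to compound 4 (beyond the scatter) is expected, resting on a number at least 3 percentage points lower from compound 1 to compound 2 (that floor lies within the scatter) and on compound 3 giving 27%. Compound 4 is therefore estimated at 12%, between 4% and 24%.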

Compound 4, percent of the compound remaining: 26%
Compound 4: middle estimate off by 14 percentage points, on the low side, and the stated range ends below it.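

In this assay, benzyl in place of thiophen-2-yl gave a number 1 percentage points lower from compound 3 to compound 4 (within the scatter). Two pairs set no rule for further cores, and they do not settle whether the change behaves alike on both cores: the same change on two cores in this assay, a number at least 3 percentage points lower (that floor lies within the scatter) from compound 1 to compound 2 and a number 1 percentage points lower (within the scatter) from compound 3 to compound 4; the limit leaves it open whether they differ Compound 2 gives only a limit of the assay, < 5%.

Going by these compounds, it remains open how a phenyl or a cyclohexylmethyl group at the same place would read on either core. On these data alone, the effect of a carboxylic acid or an amine in place of the long chain on the percent remaining also remains open.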